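Methyl in place of methoxycarbonyl in compound 4

The source may hold more compounds than are shown below. What is called first, only, known or untested is meant among the compounds shown, and "the series" means these compounds.

In a functional assay on MGC-803 cells (Homo sapiens) for inhibition, read by MTT assay, with a stated time of 48 h (on this read-out higher numbers stand for weaker inhibition and lower numbers for stronger inhibition), compound 2 `COC(=O)c1cc(CNc2cc(OC)c(OC)c(OC)c2)ccc1OC` gives 49600 nM and sits within the scatter of compound 1 `COc1ccc(CNc2cc(OC)c(OC)c(OC)c2)cc1Br` at 29400 nM on the high side of the numbers. Compound 3 `CC/C=C/C(=O)N(Cc1ccc(OC)c(O)c1)c1cc(OC)c(OC)c(OC)c1` gives a far lower number at 58 nM but differs from both in more than one place and offers no guide here. Compound 4 `COc1ccc(CNc2cc(OC)c(OC)c(OC)c2)cc1C` is unmeasured and carries methyl in place of methoxycarbonyl on an aromatic carbon. Among the compounds with values here, the only measured step on that carbon is small: a 1.7-fold higher number from compound 1 to compound 2 (0.23 log units; within the scatter) for methoxycarbonyl in place of bromo. The expected change in this assay is therefore a 1.7-fold lower number from compound 2 to compound 4 (0.22 log units; within the scatter) toward a lower number, with no shift beyond the scatter expected. Compound 4 is estimated at 30000 nM with 11000 nM to 75000 nM as its expected range.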

Compound 4, half-maximal inhibitory concentration: 56800 nM
The estimate for compound 4 lay 1.9-fold (0.28 log units) below the measured number; low and high end bracket the measured number.
By their numbers in this assay, from the lowest: compound 3; then compounds 1, 2 and 4 (each within the scatter of the next).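

Methyl, methoxycarbonyl and bromo on this aromatic carbon all give numbers within the scatter of one another in this assay, with a 1.1-fold higher number from compound 2 to compound 4 (0.06 log units; within the scatter) and a 1.9-fold higher number from compound 1 to compound 4 (0.29 log units; within the scatter) as the two new steps. Replacing the four heavy atoms of methoxycarbonyl, with its two hydrogen-bond acceptors, by the single carbon of methyl therefore moves nothing beyond the scatter here. No measurement explains this lack of change.

As far as these compounds go, whether an amine or a carboxylic acid on this carbon would shift the number remains open. So does whether the same holds on a different core.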